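A few compounds are considered here, and "the series" means these few. Any claim that something is new, unique, unknown or untested is made for them only; others in the source may bear on it.

Compound 1 `Cc1c(C(=O)N/N=C\c2ccccc2O)oc2cccc(O)c12` is the subject of this account. In a functional assay on PC-3 cells (Homo sapiens) for inhibition (a higher number here means a weaker inhibitor, a lower number a stronger inhibitor), compound 1 gives 8350 nM, the highest of the two numbers reported, though compound 2 `Cc1ccc(O)c(/C=N\NC(=O)c2oc3cccc(O)c3c2C)c1` sits close by with 7350 nM, and the step of a 1.1-fold lower number from compound 1 to compound 2 (0.06 log units; within the scatter) lies within the scatter. Compound 3 `Cc1c(C(=O)N/N=C\c2ccco2)oc2cccc(O)c12` returns only a limit of the assay, >= 40000 nM, at the limit of >= 40000 nM in this assay, at which 1 of the 3 values shown sits.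

The step to compound 4 `Cc1c(C(=O)N/N=C\c2ccc(F)cc2)oc2cccc(O)c12` makes one change, (4-fluorophenyl in place of 2-hydroxyphenyl on a carbon with a double bond to nitrogen). The measured steps that bear on it are those in which the 2-hydroxyphenyl group is exchanged for another ring: an at least 4.7-fold higher number from compound 1 to compound 3 (0.68 log units; beyond the scatter) and an at least 5.4-fold higher number from compound 2 to compound 3 (0.73 log units; beyond the scatter), both at least modest rises. Removing the hydroxyl-bearing ring in favour of 4-fluorophenyl is expected to move in the same direction, though perhaps less far, since a six-membered aromatic ring of carbon only remains. For compound 4 the number in this assay is therefore estimated at 20000 nM, with a range from 8000 nM to 50000 nM, which would mean an expected step of a 2.4-fold higher number from compound 1 to compound 4 (0.38 log units; beyond the scatter).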

Compound 4, half-maximal inhibitory concentration: >= 40000 nM
Compound 4 ended at the assay's limit; the forecaster's own chance of this, stated with the estimate: 35%; middle value at least 2.0-fold (0.30 log units) away from the limit.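

Compound 4 keeps a six-membered aromatic ring of carbon only on the carbon with a double bond to nitrogen, yet this assay shows an at least 4.7-fold higher number from compound 1 to compound 4 (0.68 log units; beyond the scatter) and an at least 5.4-fold higher number from compound 2 to compound 4 (0.73 log units; beyond the scatter). The earlier rises came with furan-2-yl, whereas this one shows that a six-membered aromatic ring of carbon alone does not retain a readable number; among the compounds shown, only compound 1 and compound 2, whose rings carry a hydroxyl, give one. Compound 4 stands at a limit of the assay, as does compound 3, so the step between them cannot be read: the limit of >= 40000 nM in this assay, at which 2 of the 4 values shown sit.

On these data alone, this single change removes the hydroxyl and adds fluorine together, so the part played by each remains open. As far as these compounds go, how a plain phenyl or a 2-methoxyphenyl group would read on this carbon also remains open.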